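This account rests on a few compounds, and the source may have more. Where it says the series, first, only, none or still open, it means among the compounds named here.

Working notes on the amide-nitrogen substituent series.

Of the compounds shown here, two carry a number so far. Compound 1, `CCCCCCCCCCCC(=O)OC[C@H](CSC[C@@H](N)C(=O)N[C@H](C)CO)OC(=O)CCCCCCCCCCC`, is the weaker of the pair: in an assay on HEK293 cells for agonist activity at Toll-like receptor 2 (Homo sapiens) (a higher number here means that more compound is needed for the effect, a lower number that less compound is needed), compound 1 gives 22200 nM. Among the measured compounds shown here, compound 2, `CCCCCCCCCCCC(=O)OC[C@H](CSC[C@@H](N)C(=O)NC(C)CCC(C)C)OC(=O)CCCCCCCCCCC`, gives 190 nM in this assay, the lower of the two numbers; its nearest neighbour is compound 1, and the single step of a 120-fold lower number from compound 1 to compound 2 (2.07 log units; beyond the scatter) separates them, a change from a small oxygen-bearing group to a plain hydrocarbon chain on the amide-type nitrogen.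

Compound 3, `CCCCCCCCCCCC(=O)OC[C@H](CSC[C@@H](N)C(=O)N[C@@H](CC)COCC(=O)O)OC(=O)CCCCCCCCCCC`, is not yet measured in this assay. It differs from compound 2 as follows: 1-((carboxymethoxy)methyl)propyl in place of 1,4-dimethylpentyl on an amide-type nitrogen. For the measured compounds named here, the only step that bears on it is a 120-fold lower number from compound 1 to compound 2 (2.07 log units; beyond the scatter), which rewarded the removal of donors and acceptors from this position. Compound 3 reverses that direction, bringing back one donor and two acceptors, so a higher number than compound 2 is expected in this assay, beyond the scatter, though not necessarily all the way back to compound 1. For compound 3 the estimate is 4000 nM, within 700 nM to 25000 nM, which means an expected step of a 21-fold higher number from compound 2 to compound 3 (1.32 log units; beyond the scatter).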

Compound 3, half-maximal effective concentration: 6500 nM
Compound 3: middle estimate off by 1.6-fold (0.21 log units), on the low side, and the stated range covers the measured number.
By their numbers in this assay, from the lowest: compound 2; then compound 3; then compound 1.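

In this assay, 1-((carboxymethoxy)methyl)propyl in place of 1,4-dimethylpentyl on the amide-type nitrogen gives a 34-fold higher number from compound 2 to compound 3 (1.53 log units; beyond the scatter), so the hydrocarbon substituent keeps the lowest number among the three compounds. The two oxygen-bearing substituents also separate from each other: 1-((carboxymethoxy)methyl)propyl in place of 1-(hydroxymethyl)ethyl gives a 3.4-fold lower number from compound 1 to compound 3 (0.53 log units; beyond the scatter), which places compound 3 between the other two compounds and shows that this position does not treat all oxygen-bearing groups alike. No measurement shown explains either step.

The compounds shown cannot separate the contribution of the carboxylic acid from that of the ether oxygen in 1-((carboxymethoxy)methyl)propyl, a question that a methyl ester or a plain alkyl ether on the same chain would address. Also open, from the compounds shown here alone, are how a primary amine or a longer straight alkyl chain on this nitrogen would read, and whether the defined stereocentre of compound 3 matters to its number.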